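Replacing the dithiocarbamate tail with a bromobutyl chain

The source may report more compounds than this note shows. Statements on the series, on what has been measured and on what is new or still open speak of the compounds shown alone.

Measured compounds:
compound 1 `COc1ccc(-c2coc3cc(OCCCSC(=S)N4CCN(C)CC4)ccc3c2=O)cc1`: 24200 nM
compound 2 `CCN1CCN(C(=S)SCCCOc2ccc3c(=O)c(-c4ccc(OC)cc4)coc3c2)CC1`: 36900 nM
compound 3 `COc1ccc(-c2coc3cc(OCCCSC(=S)N4CCCC4)ccc3c2=O)cc1`: 30800 nM

In a functional assay on ECa-109 cells for inhibition, with ECa-109 cell line (Homo sapiens) as the target, read by MTT assay, with a stated time of 48 h (a lower number here means a stronger inhibitor, a higher number a weaker inhibitor), compound 3 stands second highest of the three numbers, with compound 2 nearest, a step of a 1.2-fold lower number from compound 2 to compound 3 (0.08 log units; within the scatter), and compound 1 furthest, a step of a 1.3-fold higher number from compound 1 to compound 3 (0.10 log units; within the scatter). Compound 4 `COc1ccc(-c2coc3cc(OCCCCBr)ccc3c2=O)cc1` differs from compound 3 by a group of 2 heavy atoms (1 carbon, 1 bromine; no ring) in place of a group of 8 heavy atoms (5 carbon, 1 nitrogen, 2 sulfur; one five-membered non-aromatic ring with 1 hetero atom), on a saturated chain carbon, three bonds along the chain from an oxygen on an aromatic ring. For the measured compounds named here, no measured step bears on this change: the steps of a 1.5-fold higher number from compound 1 to compound 2 (0.18 log units; within the scatter) and a 1.3-fold higher number from compound 1 to compound 3 (0.10 log units; within the scatter) only vary the group on the thiocarbonyl carbon, which here leaves altogether. The estimate for compound 4 therefore rests on the shared core alone and carries a wide range; compound 4 is expected at 45000 nM, between 15000 nM and 140000 nM, a step of a 1.5-fold higher number from compound 3 to compound 4 (0.16 log units; within the scatter).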

Compound 4, half-maximal inhibitory concentration: 66300 nM
Beside the measured number, compound 4's estimate is 1.5-fold (0.17 log units) below it; the measured number falls inside the stated range.
By their numbers in this assay, from the lowest: compounds 1, 3, 2 and 4 (each within the scatter of the next, the first and the last beyond it).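

In this assay, for the compounds shown here, the bromomethyl change gives the first steps at this position beyond the scatter, both modest: a 2.2-fold higher number from compound 3 to compound 4 (0.33 log units; beyond the scatter) and a 2.7-fold higher number from compound 1 to compound 4 (0.44 log units; beyond the scatter). Against the third tail the change stays within the scatter, with a 1.8-fold higher number from compound 2 to compound 4 (0.25 log units; within the scatter), so the loss of the tail does not separate compound 4 from all three dithiocarbamates. No evidence is available to explain these steps. The compounds shown leave open whether the bromine itself matters, and whether an amine or a hydroxyl group at the chain end would give a number nearer to those of the dithiocarbamates.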